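From Trifluoromethyl to Chloro: Expecting Little Change

The source may hold more compounds than are shown below. What is called first, only, known or untested is meant among the compounds shown, and "the series" means these compounds.

Of the compounds shown here, two that share one core have been measured in a functional assay on NCI-H226 cells (Homo sapiens) for inhibition, read by sulforhodamine B assay, with a stated time of 48 h; on this read-out lower numbers stand for stronger inhibition of growth and higher numbers for weaker inhibition of growth. Compound 1 `COc1cc2cc(Oc3ccc(NC(=O)Nc4cccc(C(F)(F)F)c4)cc3)c(C)nc2cc1OC` gives 5600 nM. Going by the values given here, compound 2 `COc1cc2cc(Oc3ccc(NC(=O)Nc4ccc(Cl)c(C(F)(F)F)c4)cc3)c(C)nc2cc1OC` gives 5010 nM; these two numbers lie within the scatter of each other, and the single measured step, a 1.1-fold lower number from compound 1 to compound 2 (0.05 log units; within the scatter), is accordingly too small to be read as a real difference. Compound 3 `COc1cc2cc(Oc3ccc(NC(=O)Nc4ccc(Cl)c(Cl)c4)cc3)c(C)nc2cc1OC` has not yet been measured in this assay. It differs from compound 2 by chloro in place of trifluoromethyl on an aromatic carbon. Among the compounds with values here, no measured step in this small set replaces a trifluoromethyl with a chloro, so nothing bears on this change directly; the only guidance is that the one change tried on this ring so far left the number within the scatter. The expected step of a 1.2-fold higher number from compound 2 to compound 3 (0.08 log units; within the scatter) is therefore small, with no direction claimed beyond the scatter. Compound 3 is thus estimated to give about 6000 nM, within a range from 2500 nM to 14000 nM.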

Compound 3, concentration for total growth inhibition: 8680 nM
Compound 3: middle estimate off by 1.4-fold (0.16 log units), on the low side; measured number inside the range.
By their numbers in this assay, from the lowest: compounds 2, 1 and 3 (each within the scatter of the next).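

In this assay, chloro in place of trifluoromethyl at this position, ortho to a chloro group, gives a 1.7-fold higher number from compound 2 to compound 3 (0.24 log units; within the scatter), so a single chlorine atom can stand where the four heavy atoms of trifluoromethyl stood without a step beyond the scatter. Compared with the unchlorinated parent, 3,4-dichlorophenyl in place of 3-(trifluoromethyl)phenyl gives a 1.6-fold higher number from compound 1 to compound 3 (0.19 log units; within the scatter), and this wider exchange also stays within the scatter. No supporting measurement is available to explain these numbers.

The three compounds leave open whether any group at this position can move the number beyond the scatter, for example an amine, a carboxylic acid or a nitrile. They also leave open whether such a group would shift the number toward stronger or weaker inhibition of growth.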